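Compound 4: a swapped ring and its expected stability

A few compounds are considered here, and "the series" means these few. Any claim that something is new, unique, unknown or untested is made for them only; others in the source may bear on it.

- compound 1 `CC1=C(c2nc(-c3ccc(C#N)cc3)cs2)C(c2ccc(Cl)nc2)NC(=O)N1`: 63.4%
- compound 2 `CC1=C(c2nc(-c3ccc(C#N)cc3)cs2)C(c2ccc(Br)nc2)NC(=O)N1`: 67.6%
- compound 3 `COc1ccc(C2NC(=O)NC(C)=C2c2nc(-c3ccc(C#N)cc3)cs2)cn1`: 69.4%

In an ADME assay on microsomes from liver (Rattus norvegicus) for metabolic stability, read by LC-MS, using NADPH, with stated times of 5 min and 60 min, tested at 4 uM (a higher number here means that more of the compound is left, a lower number that less of the compound is left), the three compounds cannot be told apart: compound 3 gives 69.4%, within the scatter of the other two. Compound 4 `CC1=C(c2nc(-c3ccc(C#N)cc3)cs2)C(c2ccc(O)cc2)NC(=O)N1` carries 4-hydroxyphenyl in place of 6-methoxypyridin-3-yl on a saturated ring carbon. The nearest evidence comes from swapping one group on an aromatic carbon: a number 4.2 percentage points higher from compound 1 to compound 2 (within the scatter), a number 6 percentage points higher from compound 1 to compound 3 (within the scatter) and a number 1.8 percentage points higher from compound 2 to compound 3 (within the scatter). None of these steps replaced a whole ring, so they guide this change only loosely. The expected step is small and not beyond the scatter, an estimated a number 5.4 percentage points lower from compound 3 to compound 4 (within the scatter). For compound 4 the estimated value is 64%, with an expected range from 42% to 82%.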

Compound 4, percent of the compound remaining: 100%
Compound 4: the middle estimate sits 36 percentage points below what was measured; the whole stated range lies below it.
By their numbers in this assay, from the lowest: compounds 1, 2 and 3 (each within the scatter of the next); then compound 4.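

In this assay, the group on this saturated ring carbon turns out to matter far more than the earlier swaps suggested: a number 30.6 percentage points higher from compound 3 to compound 4 (beyond the scatter), a number 32.4 percentage points higher from compound 2 to compound 4 (beyond the scatter) and a number 36.6 percentage points higher from compound 1 to compound 4 (beyond the scatter). Exchanging only chloro, bromo or methoxy on the ring had stayed within the scatter, whereas replacing the whole ring with 4-hydroxyphenyl does not. Nothing measured here explains this gain. Compound 4 loses the ring nitrogen and also gains a hydroxy group, so the compounds shown cannot separate these two changes. As far as these compounds go, whether an amine in place of that hydroxy group would give a similar number also stays open.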